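This account rests on a few compounds, and the source may have more. Where it says the series, first, only, none or still open, it means among the compounds named here.

Measured so far, in an assay on HEK293 cells for displacement of a labelled ligand from NPC1-like intracellular cholesterol transporter 1 (Homo sapiens); on this read-out lower numbers stand for stronger inhibition and higher numbers for weaker inhibition:
compound 1 `CC(C)(C)c1ccc(C(=O)N2CCC3(CC2)C(=O)N(CC(=O)NCN)CN3c2ccccc2)cc1` — 26500 nM
compound 2 `CC(C)(C)c1ccc(C(=O)N2CCC3(CC2)C(=O)N(CC(=O)N2CCCCC2CCO)CN3c2ccccc2)cc1` — 6100 nM

Compound 2 holds the lowest of the two numbers in this assay; its nearest neighbour is compound 1, which sits higher by the step of a 4.3-fold lower number from compound 1 to compound 2 (0.64 log units; beyond the scatter) read in reverse, a modest gap that lies beyond the scatter. Compound 3 `CC(C)(C)c1ccc(C(=O)N2CCC3(CC2)C(=O)N(CC(=O)NCCCN)CN3c2ccccc2)cc1` differs from compound 2 in one place: (3-aminopropyl)amino in place of 2-(2-hydroxyethyl)piperidin-1-yl on a carbonyl carbon. Going by the values given here, the only step that bears on this change is a 4.3-fold lower number from compound 1 to compound 2 (0.64 log units; beyond the scatter), in which an amine-bearing open chain on the same carbonyl carbon was exchanged for the hydroxyethyl-substituted piperidine. Compound 3 returns to an amine-bearing open chain, longer by two chain carbons than that of compound 1. A partial reversal toward compound 1 is therefore expected, so the step of a 2.5-fold higher number from compound 2 to compound 3 (0.39 log units; beyond the scatter) is estimated to run toward higher numbers, though the longer chain leaves the size uncertain. On that basis compound 3 is expected to give about 15000 nM in this assay, with a range from 5000 nM to 40000 nM.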

Compound 3, half-maximal inhibitory concentration: 4200 nM
Estimate against measurement, compound 3: 3.6-fold (0.55 log units) above; the measured number lies below the stated range.
By their numbers in this assay, from the lowest: compounds 3 and 2 (each within the scatter of the next); then compound 1.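

In this assay, the exchange on this carbonyl carbon gives a 1.5-fold lower number from compound 2 to compound 3 (0.16 log units; within the scatter), so the open (3-aminopropyl)amino chain and the ring-bearing 2-(2-hydroxyethyl)piperidin-1-yl group cannot be told apart at this position, and a ring is not required to reach this level. The comparison of the two open chains, with 2-aminoethyl in place of amino on a saturated chain carbon bound to an amide-type nitrogen, gives a 6.3-fold lower number from compound 1 to compound 3 (0.80 log units; beyond the scatter), so the earlier gap of a 4.3-fold lower number from compound 1 to compound 2 (0.64 log units; beyond the scatter) can no longer be read as a difference between ring and open chain, since chain length alone, with the terminal amine kept, gives a step beyond the scatter. The data offer no explanation for either step.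

Still open, as far as these compounds go, is whether the number keeps falling with a longer chain, such as (4-aminobutyl)amino, or levels off at the length of compound 3. Also open, from the compounds shown here alone, is whether the terminal amine matters at all, which a hydroxyl or a carboxylic acid at the chain end would test, and whether the hydroxyethyl arm of compound 2 contributes, which a plain piperidine would test.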